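A benzyl swap at the sulfonyl of compound 1

The source may hold more compounds than are shown below. What is called first, only, known or untested is meant among the compounds shown, and "the series" means these compounds.

Compound 1 `CC1(C(=O)NS(=O)(=O)c2ccc(Cl)s2)CCN(c2nc3c(cc2C#N)C(=O)OC3)CC1`: 1640 nM
Compound 2 `N#Cc1cc2c(nc1N1CCC(F)(C(=O)NS(=O)(=O)c3ccc(Cl)s3)CC1)COC2=O`: 37100 nM
Compound 3 `N#Cc1cc2c(nc1N1CCC(C(=O)NS(=O)(=O)c3ccc(Cl)s3)CC1)COC2=O`: 4470 nM

In a functional assay (Platelet, plasma) for inhibition, with Homo sapiens as the target (on this read-out higher numbers stand for weaker inhibition and lower numbers for stronger inhibition), compound 1 gives the lowest of the three numbers, 1640 nM, and so shows the strongest inhibition of the three. The nearest compound lies beyond the scatter, with a 2.7-fold higher number from compound 1 to compound 3 (0.44 log units; beyond the scatter), and the furthest shows a 23-fold higher number from compound 1 to compound 2 (1.35 log units; beyond the scatter). The remaining measured step is an 8.3-fold lower number from compound 2 to compound 3 (0.92 log units; beyond the scatter).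

Compound 4 `CC1(C(=O)NS(=O)(=O)Cc2ccccc2)CCN(c2nc3c(cc2C#N)C(=O)OC3)CC1` keeps the shared core and the methyl of compound 1 but changes the other end of the molecule: benzyl in place of 5-chlorothiophen-2-yl on a sulfonyl sulfur. In words, this is benzyl in place of 5-chlorothiophen-2-yl on a sulfonyl sulfur. Among the measured compounds shown here, all three measured steps concern a saturated ring carbon, and no measured compound varies the group on the sulfonyl sulfur. They therefore bear on this change only indirectly, and they give no direction for it. They do show that a single change elsewhere can move the number in this assay by a modest to large step, so a wide range is warranted. No step beyond the scatter is confidently expected in either direction. The expected step is a 1.3-fold higher number from compound 1 to compound 4 (0.13 log units; within the scatter). The estimate for compound 4 is 2200 nM, with an expected range of 500 nM to 9000 nM.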

Compound 4, half-maximal inhibitory concentration: 6680 nM
Estimate against measurement, compound 4: 3.0-fold (0.48 log units) below; low and high end bracket the measured number.
By their numbers in this assay, from the lowest: compound 1; then compounds 3 and 4 (each within the scatter of the next); then compound 2.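

In this assay the group on the sulfonyl sulfur now has a measured step of its own: benzyl in place of 5-chlorothiophen-2-yl gives a 4.1-fold higher number from compound 1 to compound 4 (0.61 log units; beyond the scatter) and so weakens inhibition, which shows that this end of the molecule also affects the number when the methyl and the shared core stay fixed. This step is modest, and it does not reach the large step on the saturated ring carbon, a 23-fold higher number from compound 1 to compound 2 (1.35 log units; beyond the scatter) in the same assay. The swap replaces a five-membered aromatic ring holding sulfur and chlorine with a six-membered aromatic ring of carbon only, and the compounds shown offer no measurement that accounts for the loss.

As far as these compounds go, it remains open which part of this swap carries the step, since a phenyl, a thiophen-2-yl without chlorine or a chlorobenzyl on the sulfonyl sulfur would each separate the ring, the chlorine and the added carbon. From the compounds shown here alone, it is also open whether the step keeps its direction and size when hydrogen or fluoro replaces the methyl on the saturated ring carbon.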